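The source may hold more compounds than are shown below. What is called first, only, known or untested is meant among the compounds shown, and "the series" means these compounds.

Measured so far in an ADME assay on WI-38 cells (Homo sapiens) for cytotoxicity, read by MTT assay, with a stated time of 72 h; on this read-out higher numbers stand for weaker inhibition and lower numbers for stronger inhibition:
compound 1 `COc1ccc(/C=N/NC(=O)Nc2ccc(Oc3ccnc(-c4nncn4CCN(C)C)c3)c(F)c2)c(OC)c1` gives 6630 nM
compound 2 `COc1ccc(/C=N/NC(=O)Nc2ccc(Oc3ccnc(-c4nncn4CCN(C)C)c3)c(F)c2)c(OC)c1OC` gives "not determined" (no result reported)
compound 3 `CN(C)CCn1cnnc1-c1cc(Oc2ccc(NC(=O)N/N=C/c3cccc(Cl)c3Cl)cc2F)ccn1` gives 6130 nM

Compound 3 holds the lower of the two numbers in this assay, but its nearest neighbour, compound 1, sits within the scatter of it, so no order between the two can be read from these data. Going by the values given here, the single step that can be measured, a 1.1-fold lower number from compound 1 to compound 3 (0.03 log units; within the scatter), replaced one substituted phenyl group by another on the carbon with a double bond to nitrogen and left the number essentially unchanged.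

Compound 4 `CN(C)CCn1cnnc1-c1cc(Oc2ccc(NC(=O)N/N=C/c3cccc(Br)c3)cc2F)ccn1` continues at the same place: 3-bromophenyl in place of 2,3-dichlorophenyl on a carbon with a double bond to nitrogen. Among the compounds with values here, the only measured step that bears on this change is a 1.1-fold lower number from compound 1 to compound 3 (0.03 log units; within the scatter), and it was within the scatter. Nothing in the measured set separates one halogenated phenyl group from another, so there is no basis for expecting a shift beyond the scatter in either direction. Compound 4 is accordingly estimated to give 6000 nM in this assay, with a range from 3000 nM to 12000 nM. This is expected to amount to a step of a 1.0-fold lower number from compound 3 to compound 4 (0.01 log units; within the scatter), which is no larger than the scatter.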

Compound 4, half-maximal inhibitory concentration: 4230 nM
For compound 4 the middle estimate is 1.4-fold (0.15 log units) above the measured one, and the stated range covers the measured number.
By their numbers in this assay, from the lowest: compounds 4, 3 and 1 (each within the scatter of the next).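

In this assay, 3-bromophenyl on a carbon with a double bond to nitrogen gives a 1.4-fold lower number from compound 3 to compound 4 (0.16 log units; within the scatter) when it replaces 2,3-dichlorophenyl, and a 1.6-fold lower number from compound 1 to compound 4 (0.20 log units; within the scatter) when it replaces 2,4-dimethoxyphenyl. Where the earlier compounds offered a single readable step, three different substituted phenyl groups can now be compared at this place, with two chlorine atoms, one bromine atom or two methoxy groups on the ring, and the measured steps separate none of them, even though the change to 3-bromophenyl leaves one heavy atom fewer than 2,3-dichlorophenyl. No other measurement is available to explain these numbers.

Compound 2 has no number in this assay, so steps involving it cannot be read. The compounds shown leave open whether a phenyl ring carrying an amine or a carboxylic acid, or a cyclohexyl ring or a longer alkyl chain in place of the phenyl ring, would keep the number within the scatter of these three compounds.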